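Moving an ethoxy group on the phenoxy ring

This account rests on a few compounds, and the source may have more. Where it says the series, first, only, none or still open, it means among the compounds named here.

compound 1 `O=C(O)COc1ccc(NC(=O)COc2ccccc2)cc1F`: 29.8%
compound 2 `CCOc1ccccc1OC(C)C(=O)Nc1ccc(OCC(=O)O)c(F)c1`: 8.79%
compound 3 `Cc1ccc(OCC(=O)Nc2ccc(OCC(=O)O)c(F)c2)cc1`: 31.2%

Three compounds sharing one core were tested in a functional assay on CHO cells for agonist activity at Free fatty acid receptor 1 (Homo sapiens), read by FLIPR, tested at 100 nM; a higher number here means a stronger effect of the compound at the concentration tested, a lower number a weaker effect. Compound 1 gives 29.8% and compound 3 gives 31.2%, while compound 2 gives 8.79%, the lowest of the three and beyond the scatter from each of the others. For the measured compounds named here, the one single-point step measured, a number 1.4 percentage points higher from compound 1 to compound 3 (within the scatter), stays within the scatter; it adds a methyl on an aromatic carbon and bears on the question only indirectly. Compound 4 `CCOc1ccc(OC(C)C(=O)Nc2ccc(OCC(=O)O)c(F)c2)cc1` is not yet measured. It differs from compound 2 by 4-ethoxyphenyl in place of 2-ethoxyphenyl on an oxygen on a saturated carbon. Going by the values given here, no measured pair tests such a rearrangement directly, so a modest step upward is expected, a number 9.2 percentage points higher from compound 2 to compound 4 (within the scatter), with wide uncertainty. Compound 4 is estimated at 18%, between 5% and 38%.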

Compound 4, a percentage reported as activity, at one concentration (the size of the read-out at that concentration, not a potency): 3.56%
Estimate against measurement, compound 4: 14.4 percentage points above, and the stated range ends above it.
By their numbers in this assay, from the lowest: compounds 4 and 2 (each within the scatter of the next); then compounds 1 and 3 (each within the scatter of the next).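

In this assay, the exchange of 2-ethoxyphenyl for 4-ethoxyphenyl on an oxygen on a saturated carbon gives a number 5.2 percentage points lower from compound 2 to compound 4 (within the scatter), so the two arrangements of the same atoms cannot be told apart at this concentration. For the compounds shown here, this is the first direct test of where the ethoxy group sits on this ring, and within this pair its placement makes no distinguishable difference. No evidence is available that bears on this result. Still open, from the compounds shown here alone, is whether an amine or a longer chain such as butoxy, in place of the ethoxy group, would give a different read-out.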